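From Bromo to Methyl on the Shared Core

This account rests on a few compounds, and the source may have more. Where it says the series, first, only, none or still open, it means among the compounds named here.

Within the data shown here, in a functional assay on A2780 cells (Homo sapiens) for cytotoxicity, read by MTT assay, with a stated time of 68 h (a higher number here means a weaker inhibitor, a lower number a stronger inhibitor), compound 2 `O=C(/C=C/c1cccc(OCc2ccccc2)c1)c1ccc(Br)cc1` gives 1800 nM, the lowest of the three numbers measured so far. Compound 1 `O=C(/C=C/c1cccc(OCc2ccccc2)c1)c1ccc([N+](=O)[O-])cc1` gives 56400 nM, and compound 3 `O=C(/C=C/c1cccc(OCc2ccccc2)c1)c1ccc(Cl)cc1` gives 56400 nM. Compound 4 `Cc1ccc(C(=O)/C=C/c2cccc(OCc3ccccc3)c2)cc1` has not yet been measured. It differs from compound 2 in one place: methyl in place of bromo on an aromatic carbon. This puts methyl in place of bromo on an aromatic carbon, para to a large group.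

Three measured steps change the group on that carbon. Bromo replacing nitro gives a 31-fold lower number from compound 1 to compound 2 (1.50 log units; beyond the scatter), and chloro replacing bromo gives a 31-fold higher number from compound 2 to compound 3 (1.50 log units; beyond the scatter). Chloro replacing nitro gives no change at the digits printed from compound 1 to compound 3 (within the scatter). Among the measured compounds shown here, only bromo therefore stands apart, and no measured compound carries methyl, so the guidance is indirect. Losing bromo raised the number in compound 3, at 56400 nM, so a rise in this assay is expected here too, though probably a smaller one. The estimated change is a 6.7-fold higher number from compound 2 to compound 4 (0.82 log units; beyond the scatter). The estimate for compound 4 is 12000 nM, with an expected range from 2000 nM to 60000 nM.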

Compound 4, half-maximal inhibitory concentration: 20500 nM
Compound 4: middle estimate off by 1.7-fold (0.23 log units), on the low side; the range from low to high includes it.
By their numbers in this assay, from the lowest: compound 2; then compound 4; then compounds 1 and 3 (each within the scatter of the next).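

Compound 2 keeps the lowest number against a third replacement in this assay, with an 11-fold higher number from compound 2 to compound 4 (1.06 log units; beyond the scatter), so none of the three other groups on this aromatic carbon matches bromo. Methyl does not simply fall back to the level shared by nitro and chloro, as the steps show a 2.8-fold lower number from compound 3 to compound 4 (0.44 log units; beyond the scatter) and a 2.8-fold lower number from compound 1 to compound 4 (0.44 log units; beyond the scatter), which gives this position an intermediate result rather than a split between bromo and everything else. No measurement available here explains this order.

Iodo and fluoro, the remaining halogens, would show whether bromo is an isolated case among them. On these data alone, an amine, a carboxylic acid or a longer chain such as ethyl on the same carbon also remains open, so the span of numbers possible at this position is still unknown.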